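The compounds below may be only part of what the source reports. "The series", "measured", "known", "first", "only" and "open" are said of these compounds alone.

In a functional assay on the whole organism (blood) with Rattus norvegicus as the target (a higher number here means that more compound is needed for the effect, a lower number that less compound is needed), compound 1 `CO/N=C(\F)C1=CCCN(C)C1` gives 0.04 mg/kg. Compound 2 `CO/N=C(\C#N)C1=CCCN(C)C1` gives > 1 mg/kg, which is a limit of the assay and not a number. Within the data shown here, the only measured step, an at least 25-fold higher number from compound 1 to compound 2 (1.39 log units; beyond the scatter), is large, but it concerns a carbon with a double bond to nitrogen. Compound 3 `CO/N=C(\C#N)C1=CCCNC1` instead differs at another place: hydrogen in place of methyl on an amine nitrogen in a ring. Among the measured compounds shown here, no measured step covers that change, so no step beyond the scatter is expected in this assay, and no direction can be given. The expected change is a step that the limit leaves unreadable from compound 2 to compound 3. For compound 3 the estimated value is 2 mg/kg, with an expected range of 0.5 mg/kg to 10 mg/kg.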

Compound 3, dose for half-maximal effect in the Rattus norvegicus assay: > 0.32 mg/kg
Compound 3: no number, only a limit; the forecaster's own chance of this, stated with the estimate: 60%; the middle value does not contradict the limit.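

In the Rattus norvegicus assay compound 2 gives > 1 mg/kg, which is a limit of the assay and not a number. In the Rattus norvegicus assay compound 3 gives > 0.32 mg/kg, which is also a limit of the assay and not a number. Among these compounds, in the Rattus norvegicus assay no step between compound 2 and compound 3 can therefore be read. As far as these compounds go, whether hydrogen in place of methyl on an amine nitrogen in a ring changes the dose needed, and in which direction, stays open. In a physicochemical assay for acid dissociation, compound 2 gives 7.65 and compound 3 gives 8.6.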